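Replacing a Cyclopropyl on the Benzimidazole Nitrogen with a Larger Group

A few compounds are considered here, and "the series" means these few. Any claim that something is new, unique, unknown or untested is made for them only; others in the source may bear on it.

Measured compounds:
compound 1, `CC(C)c1onc(-c2c(Cl)cccc2Cl)c1COc1ccc(-c2nc3cc(C(=O)O)ccc3n2C)cc1`, 25.8 nM
compound 2, `CC(C)c1onc(-c2c(Cl)cccc2Cl)c1COc1ccc(-c2nc3ccc(C(=O)O)cc3n2C2CC2)cc1`, 16.5 nM
compound 3, `CC(C)c1onc(-c2c(Cl)cccc2Cl)c1COc1ccc(-c2nc3ccc(C(=O)O)cc3n2C)cc1Cl`, 19 nM

In an assay on Huh-7 cells for agonist activity at Bile acid receptor (Homo sapiens), read by a luciferase reporter (a higher number here means that more compound is needed for the effect, a lower number that less compound is needed), compound 2 gives 16.5 nM, which is the lowest of the three numbers, though its distance to compound 3 and to compound 1 stays within the usual scatter, so none of the three can be set above or below the others. No two of these compounds differ in only one place, so no single structural step has been measured here.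

Compound 4, `CC(=O)C1CCC(Cn2c(-c3ccc(OCc4c(-c5c(Cl)cccc5Cl)noc4C(C)C)cc3)nc3ccc(C(=O)O)cc32)CC1`, has not yet been measured. Compared with compound 2, the difference is (4-acetylcyclohexyl)methyl in place of cyclopropyl on an aromatic nitrogen. Going by the values given here, the group that enters is considerably larger than the one that leaves and carries a carbonyl, but nothing among the measured compounds shows how a change on this aromatic nitrogen plays out, since the cyclopropyl of compound 2 and the methyl of compounds 1 and 3 are never compared on otherwise identical structures.

The author therefore expects only a small step from compound 2 to compound 4, a 1.2-fold higher number from compound 2 to compound 4 (0.08 log units; within the scatter), not clearly beyond the scatter in either direction. For compound 4 the estimate in this assay is 20 nM, with a range from 6 nM to 70 nM.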

Compound 4, half-maximal effective concentration: 1170 nM
For compound 4 the middle estimate is 59-fold (1.77 log units) below the measured one, and the stated range ends below it.
By their numbers in this assay, from the lowest: compounds 2, 3 and 1 (each within the scatter of the next); then compound 4.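

In this assay, going by these compounds alone, the exchange of cyclopropyl for (4-acetylcyclohexyl)methyl on an aromatic nitrogen gives a 71-fold higher number from compound 2 to compound 4 (1.85 log units; beyond the scatter) and so provides the first single-place step at this position. It shows that the number in this assay can depend strongly on the group at this nitrogen, and that this particular exchange moves it well beyond the scatter. The earlier compounds shown here could not show this, since they stood within the scatter of one another and no two of them differed in only one place. No measurement at hand accounts for the size of this step.

The exchange changes several things at once, bringing in a six-membered carbon ring, a connecting methylene and an acetyl carbonyl, so the compounds shown do not separate the contribution of any one of these parts. As far as these compounds go, it remains open whether a plain cyclohexylmethyl without the acetyl, or a smaller group such as ethyl, would stay close to compound 2 or would also give a much higher number.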